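This account rests on a few compounds, and the source may have more. Where it says the series, first, only, none or still open, it means among the compounds named here.

Compound 1, `COc1ccc(SCc2ccc(/C=C/C(=O)Nc3ccccc3N)cc2)cc1OC`: 80.6%
Compound 2, `Nc1ccccc1NC(=O)c1ccc(CSc2cccc(F)c2)cc1`: 72.7%

In a functional assay on A549 cells (Homo sapiens) for inhibition, read by CCK-8 assay, with a stated time of 72 h, tested at 8 uM (a lower number here means less inhibition of growth, a higher number more inhibition of growth at the concentration tested), compound 1 gives 80.6% and stands highest of the two numbers shown, though compound 2, which gives 72.7% in this assay, lies within the usual scatter of it, so the two are not told apart. For the measured compounds named here, no two measured compounds differ in only one place, so no measured step is available to guide the next change. Compound 3, `CC(C)(C)c1ccc(SCc2ccc(/C=C/C(=O)Nc3ccccc3N)cc2)cc1`, differs from compound 1 by 4-(tert-butyl)phenyl in place of 3,4-dimethoxyphenyl on a sulfur. With nothing measured on such a change, only a step of modest size in this assay is expected, pointing somewhat downward but not clearly beyond the scatter. Compound 3 is therefore estimated to give 74% in this assay, within a range from 55% to 90%. The step expected is a number 6.6 percentage points lower from compound 1 to compound 3 (within the scatter).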

Compound 3, percent growth inhibition at one concentration: 79.8%
Compound 3: the middle estimate sits 5.8 percentage points below what was measured; the range from low to high includes it.
By their numbers in this assay, from the lowest: compounds 2, 3 and 1 (each within the scatter of the next).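

On the sulfur whose other neighbour is a saturated chain carbon, this assay now has its first measured step: 4-(tert-butyl)phenyl in place of 3,4-dimethoxyphenyl gives a number 0.8 percentage points lower from compound 1 to compound 3 (within the scatter). The two groups match in heavy-atom count and each holds one six-membered aromatic ring of carbon only, yet the entering group has only carbon and no hydrogen-bond acceptors, so on this core and in this assay the oxygens of the leaving group are not needed to keep the number within the scatter. No measurement here accounts for this result.

Going by these compounds, whether a different kind of group on this sulfur, such as an amine or a carboxylic acid on the ring, would move the number beyond the scatter remains open. Also open, on these data alone, is whether the same exchange would behave alike on the core of compound 2.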